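Swapping Propoxycarbonyl for 4-Methylpyrimidin-2-yl

The source may hold more compounds than are shown below. What is called first, only, known or untested is meant among the compounds shown, and "the series" means these compounds.

Two related compounds have been measured so far, compound 1 (`COC(=O)NC(=O)c1ccsc1NC(=O)c1ccc(S(=O)(=O)N2CCCCCC2)cc1`) and compound 2 (`CCCOC(=O)NC(=O)c1ccsc1NC(=O)c1ccc(S(=O)(=O)N2CCCCC2)cc1`). In a toxicity assay on Vero cells (Chlorocebus sabaeus) for cytotoxicity, read by MTT assay (a higher number here means a weaker inhibitor, a lower number a stronger inhibitor), compound 1 gives 9.13 ug/mL and compound 2 gives 56.6 ug/mL. Compound 2 therefore holds the higher of the two numbers, and the gap between them lies beyond the usual scatter.

Compound 3 (`Cc1ccnc(NC(=O)c2ccsc2NC(=O)c2ccc(S(=O)(=O)N3CCCCC3)cc2)n1`) carries 4-methylpyrimidin-2-yl in place of propoxycarbonyl on an amide-type nitrogen. Within the data shown here, no measured pair differs in one place only, so no direct precedent exists for this change in this assay. Among the measured compounds shown here, the only guide is that compound 1, at 9.13 ug/mL, shows that a close relative can reach a much lower number. A step slightly beyond the scatter, toward a lower number, is therefore expected, and the expected step is a 2.3-fold lower number from compound 2 to compound 3 (0.35 log units; beyond the scatter). Compound 3 is estimated at 25 ug/mL, with an expected range from 6 ug/mL to 90 ug/mL.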

Compound 3, half-maximal inhibitory concentration: 32.8 ug/mL
Beside the measured number, compound 3's estimate is 1.3-fold (0.12 log units) below it; low and high end bracket the measured number.
By their numbers in this assay, from the lowest: compound 1; then compounds 3 and 2 (each within the scatter of the next).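

In this assay, putting 4-methylpyrimidin-2-yl in place of propoxycarbonyl on this amide-type nitrogen gives a 1.7-fold lower number from compound 2 to compound 3 (0.24 log units; within the scatter) and so leaves the reading within the scatter. This pair therefore shows that, on the shared core, the group on this nitrogen can change from an open chain with no ring to a six-membered aromatic ring with 2 hetero atoms without a step that can be told apart from the scatter. No measurement shown explains why these two different groups read alike.

This is a single pair, so it cannot show how far that tolerance extends. As far as these compounds go, whether a phenyl ring, a simple amine or a longer chain on this nitrogen would read the same remains open.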